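The source may hold more compounds than are shown below. What is called first, only, known or untested is meant among the compounds shown, and "the series" means these compounds.

Working notes on the series. The compounds share one core and differ only at an aromatic carbon of a five-membered aromatic ring with 2 nitrogen. Compound 1 `O=C(Nn1c(-c2cccc([N+](=O)[O-])c2)nc2c(-c3ccc(F)cc3)n[nH]c2c1=O)c1cccnc1` gives 24.9% in a functional assay on DU-145 cells (Homo sapiens) for cytotoxicity, read by sulforhodamine B assay, with a stated time of 2 days, tested at 100 uM; a higher number here means more inhibition at the concentration tested (going by the name of the read-out), a lower number less inhibition; compound 2 `O=C(Nn1c(-c2cccc([N+](=O)[O-])c2)nc2c(-c3ccco3)n[nH]c2c1=O)c1cccnc1` gives 1.66%; compound 3 `O=C(Nn1c(-c2cccc([N+](=O)[O-])c2)nc2c(-c3cccs3)n[nH]c2c1=O)c1cccnc1` gives 32.8%. Compound 3 holds the highest of the three numbers, with compound 1 within the scatter of it: a number 7.9 percentage points higher from compound 1 to compound 3 (within the scatter). The other steps at this position are larger: a number 23.2 percentage points lower from compound 1 to compound 2 (beyond the scatter) and a number 31.1 percentage points higher from compound 2 to compound 3 (beyond the scatter). Compound 4 `O=C(Nn1c(-c2cccc([N+](=O)[O-])c2)nc2c(CCc3ccccc3)n[nH]c2c1=O)c1cccnc1` differs from compound 3 by phenethyl in place of thiophen-2-yl on an aromatic carbon. Among the compounds with values here, no measured step swaps an aromatic ring for a chain, so the steps above bear only indirectly; they show that this position moves the read-out by modest to large amounts. For compound 4 a step of a number 14.8 percentage points lower from compound 3 to compound 4 (beyond the scatter) is expected, giving an estimated 18%, range 0% to 42%.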

Compound 4, a percentage reported as inhibition, at one concentration (the size of the read-out at that concentration, not a potency): 22.5%
For compound 4 the middle estimate is 4.5 percentage points below the measured one, within the range that was stated.
By their numbers in this assay, from the lowest: compound 2; then compounds 4, 1 and 3 (each within the scatter of the next, the first and the last beyond it).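

In this assay the position also accepts phenethyl, a chain-borne phenyl, and not only the aromatic rings seen so far: a number 10.3 percentage points lower from compound 3 to compound 4 (beyond the scatter) and a number 20.8 percentage points higher from compound 2 to compound 4 (beyond the scatter) and a number 2.4 percentage points lower from compound 1 to compound 4 (within the scatter). Compound 4 therefore sits with the aromatic-ring compounds 1 and 3, leaving the furan-2-yl of compound 2 alone at the low end of the four. No measurement offered here explains these differences. On these data alone, whether benzyl, a longer chain or an amine in place of phenethyl would change the number remains open.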